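This account rests on a few compounds, and the source may have more. Where it says the series, first, only, none or still open, it means among the compounds named here.

Four compounds are compared here, all built on one shared core. Compound 1 has the structure `CCC(C)OC(=O)C1=C(C)NC(=O)NC1c1ccoc1`. Compound 2, with the structure `CC1=C(C(=O)OC2CCC2)C(c2ccoc2)NC(=O)N1`, differs from compound 1 in a single change: cyclobutyl in place of sec-butyl on an oxygen next to a carbonyl group. Compound 3 has the structure `CCC(C)OC(=O)C1=C(C)NC(=O)NC1c1ccsc1`. Compound 4, with the structure `CC1=C(C(=O)OC2CCC2)C(c2ccsc2)NC(=O)N1`, has not been measured yet.

In an assay on membranes from CHO cells for displacement of a labelled ligand from adenosine receptor A1 (Homo sapiens), read by scintillation counting, with a stated time of 60 min, tested at 1 uM (on this read-out higher numbers stand for more inhibition at the one concentration tested (going by the name of the read-out) and lower numbers for less inhibition), compound 1 gives 13%. In this assay compound 2 gives 20%, which is a step of a number 7 percentage points higher from compound 1 to compound 2 (within the scatter). In this assay compound 3 gives 5%, which is a step of a number 8 percentage points lower from compound 1 to compound 3 (within the scatter).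

Compound 4 differs from compound 3 by cyclobutyl in place of sec-butyl on an oxygen next to a carbonyl group. This is the same change that leads from compound 1 to compound 2, and the place where it happens is described in the same words in both pairs, so the change is the same, only made on a different core. The two cores differ by thiophen-3-yl in place of furan-3-yl on a saturated ring carbon.

Because the step of a number 7 percentage points higher from compound 1 to compound 2 (within the scatter) was small, a step of about the same size is expected for compound 4, namely a number 7 percentage points higher from compound 3 to compound 4 (within the scatter), which on this read-out would mean that the cyclobutyl ester of compound 3 behaves much like compound 3 itself. For compound 4 in this assay an inhibition of about 12% is estimated, with a likely range from 0% to 25%.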

Compound 4, a percentage reported as inhibition, at one concentration (the size of the read-out at that concentration, not a potency): 40%
The estimate for compound 4 lay 28 percentage points below the measured number; measured number outside the range, above it.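

In this assay, putting cyclobutyl in place of sec-butyl on the thiophen-3-yl core gives a step of a number 35 percentage points higher from compound 3 to compound 4 (beyond the scatter), so the small step seen on the furan-3-yl core does not carry over: the same change on two cores in this assay, a number 7 percentage points higher (within the scatter) from compound 1 to compound 2 and a number 35 percentage points higher (beyond the scatter) from compound 3 to compound 4, 28 percentage points apart, beyond the scatter of two such steps. Looked at the other way, thiophen-3-yl in place of furan-3-yl, with cyclobutyl present, gives a step of a number 20 percentage points higher from compound 2 to compound 4 (beyond the scatter), and this also fails to match the same change made with sec-butyl present: the same change on two cores in this assay, a number 8 percentage points lower (within the scatter) from compound 1 to compound 3 and a number 20 percentage points higher (beyond the scatter) from compound 2 to compound 4, 28 percentage points apart, beyond the scatter of two such steps. Together, these four compounds show that the two changes do not simply add up, so a step read on one core was a poor guide to the same step on the other, but they do not show why this happens, whether it holds for other groups, or how potency changes, since each number is an inhibition read at a single concentration.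

The compounds shown leave open whether a larger ring such as cyclopentyl, or a longer chain such as n-hexyl, on the oxygen next to the carbonyl group would also give a higher number on the thiophen-3-yl core than on the furan-3-yl core. They also leave open whether a phenyl group on the saturated ring carbon would pair with cyclobutyl in the way thiophen-3-yl does.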